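Methyl to methoxy in a naphthoic acid retinoid series

A few compounds are considered here, and "the series" means these few. Any claim that something is new, unique, unknown or untested is made for them only; others in the source may bear on it.

Compound 2 `Cc1cc2c(cc1C(=O)c1ccc3cc(C(=O)O)ccc3c1)C(C)(C)CCC2(C)C` is the upper of the two measured compounds in an assay on isolated protein with retinoic acid receptor gamma (Homo sapiens) as the target (a lower number here means a smaller maximal response, a higher number a larger maximal response), where compound 2 gives 58%. Among the compounds with values here, compound 1 `COc1c(C(=O)c2ccc3cc(C(=O)O)ccc3c2)ccc2c1C(C)(C)CCC2(C)C`, the only other compound measured, gives 0% in this assay, a gap beyond the scatter. Compound 3 `COc1cc2c(cc1C(=O)c1ccc3cc(C(=O)O)ccc3c1)C(C)(C)CCC2(C)C` is not yet measured. From compound 2 to compound 3 the change is methoxy in place of methyl on an aromatic carbon. Within the data shown here, no step of this kind has been measured here, so the direction is open; a moderate drop is expected, since the one methoxy compound, compound 1, gives 0%. For compound 3 the expected maximal response in this assay is 40%, range 5% to 85%, a step of a number 18 percentage points lower from compound 2 to compound 3 (beyond the scatter).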

Compound 3, largest response reached (reported as maximum), in percent of the reference or control that the assay uses: 53%
The estimate for compound 3 lay 13 percentage points below the measured number, within the range that was stated.
By their numbers in this assay, from the lowest: compound 1; then compounds 3 and 2 (each within the scatter of the next).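

In this assay methoxy in place of methyl at this position, ortho to a large group, gives a number 5 percentage points lower from compound 2 to compound 3 (within the scatter) and so leaves the maximal response unchanged within the scatter. A methoxy group therefore does not by itself abolish the response: compound 3 retains one, whereas compound 1, the other methoxy compound, gives 0% in this read-out. Nothing on hand bears on why the response holds here. On these data alone, whether a hydroxyl, an ethyl or an amine at this position would also retain the response remains open.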